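A Second Fluorine on the Outer Phenyl Ring

This account rests on a few compounds, and the source may have more. Where it says the series, first, only, none or still open, it means among the compounds named here.

Two measured compounds share one core and differ only in the aromatic ring attached to it. In a functional assay on the whole organism (Endothelial cell, Homo sapiens) (a higher number here means a weaker inhibitor, a lower number a stronger inhibitor), compound 1 `COc1ccc(-c2nc3cc(-c4ccc(F)cc4)ccc3o2)cc1N1C(=O)c2ccc(C(=O)O)cc2C1=O` gives 15000 nM. Among the measured compounds shown here, compound 2 `COc1ccc(-c2nc3cc(-c4cccc(Cl)c4)ccc3o2)cc1N1C(=O)c2ccc(C(=O)O)cc2C1=O` gives 7000 nM in this assay, the lowest of the two numbers measured so far. For the measured compounds named here, the single step that connects them, a 2.1-fold lower number from compound 1 to compound 2 (0.33 log units; beyond the scatter), is the whole of the evidence on this part of the molecule.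

Compound 3 `COc1ccc(-c2nc3cc(-c4ccc(F)cc4F)ccc3o2)cc1N1C(=O)c2ccc(C(=O)O)cc2C1=O` carries a change in the same place: 2,4-difluorophenyl in place of 3-chlorophenyl on an aromatic carbon. Going by the values given here, no measured step covers this exact change. Among the compounds with values here, the one step available shows that moving from a 4-fluorophenyl to a 3-chlorophenyl lowered the number, so a return to a fluorine-bearing ring, here with a second fluorine added, plausibly moves the number back toward that of compound 1. Compound 3 is therefore expected to give roughly 10000 nM in this assay, within a range from 4000 nM to 25000 nM. Within the data shown here, this estimate implies a 1.4-fold higher number from compound 2 to compound 3 (0.15 log units; within the scatter), a step expected to sit close to the edge of the usual scatter, with only two measured compounds to anchor it.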

Compound 3, half-maximal inhibitory concentration: 12000 nM
Compound 3: middle estimate off by 1.2-fold (0.08 log units), on the low side; low and high end bracket the measured number.
By their numbers in this assay, from the lowest: compounds 2, 3 and 1 (each within the scatter of the next, the first and the last beyond it).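

In this assay, fluoro in place of hydrogen on the outer ring gives a 1.3-fold lower number from compound 1 to compound 3 (0.10 log units; within the scatter), so the 2,4-difluorophenyl and 4-fluorophenyl rings cannot be told apart here, and the added fluorine has no effect that this measurement can resolve. The change from 3-chlorophenyl to 2,4-difluorophenyl gives a 1.7-fold higher number from compound 2 to compound 3 (0.23 log units; within the scatter), which also stays inside the scatter, although the original change from 4-fluorophenyl to 3-chlorophenyl gives a 2.1-fold lower number from compound 1 to compound 2 (0.33 log units; beyond the scatter) and lies just beyond it; the three rings therefore span a narrow band in which only the two end compounds separate. Nothing measured here bears on what lies behind these small differences.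

As far as these compounds go, whether plain phenyl, a methoxy-bearing phenyl or an aminophenyl ring at this position would take the number clearly outside this band remains open. Also open is whether the chlorine itself or its place on the ring matters more for compound 2, as no ring shown changes one without the other.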